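Methoxy in place of hydroxy: expected loss of stability

The compounds below may be only part of what the source reports. "The series", "measured", "known", "first", "only" and "open" are said of these compounds alone.

In an ADME assay on microsomes from liver (Homo sapiens) for metabolic stability, tested at 1 uM (a lower number here means that the liver removes a smaller share, a higher number that the liver removes a larger share of the compound in one pass), compound 1, `CC[C@H]1OC(=O)[C@H](C)C(=O)[C@H](C)[C@@H](O[C@@H]2O[C@H](C)C[C@H](N(C)C)[C@H]2O)[C@](C)(O)C[C@@H](C)C(=O)[C@H](C)[C@H]2N(C3CN(Cc4ccnc5cccnc45)C3)C(=O)O[C@]12C`, gives 0.7. Compound 2, `CC[C@H]1OC(=O)[C@H](C)C(=O)[C@H](C)[C@@H](O[C@@H]2O[C@H](C)C[C@H](N(C)C)[C@H]2O)[C@](C)(O)C[C@@H](C)C(=O)[C@H](C)[C@H]2N(C3CN(Cc4c(O)cnc5cccnc45)C3)C(=O)O[C@]12C`, carries a hydroxy in place of hydrogen on an aromatic carbon. In this assay compound 2 reaches only a limit, < 0.3, so no exact number is known for it. Among the compounds with values here, the single measured step is a number at least 0.40 lower from compound 1 to compound 2 (beyond the scatter), and it ends at the limit (the limit of < 0.3 in this assay, at which 1 of the 2 values shown sits). Compound 3, `CC[C@H]1OC(=O)[C@H](C)C(=O)[C@H](C)[C@@H](O[C@@H]2O[C@H](C)C[C@H](N(C)C)[C@H]2O)[C@](C)(O)C[C@@H](C)C(=O)[C@H](C)[C@H]2N(C3CN(Cc4c(OC)cnc5ccccc45)C3)C(=O)O[C@]12C`, is not yet measured. It differs from compound 2 by a group of 12 heavy atoms (10 carbon, 1 nitrogen, 1 oxygen; one six-membered aromatic ring of carbon only, one six-membered aromatic ring with 1 hetero atom) in place of a group of 11 heavy atoms (8 carbon, 2 nitrogen, 1 oxygen; 2 six-membered aromatic rings with 1 hetero atom each), on a saturated chain carbon bound to an amine nitrogen in a ring; the group that enters has no hydrogen-bond donor, whereas the group that leaves has one. The hydroxy that compound 3 lacks is the change measured in a number at least 0.40 lower from compound 1 to compound 2 (beyond the scatter), so most of that large fall is expected to be given back, and compound 3 is expected to sit nearer to compound 1 than to compound 2, as a number at least 0.30 higher from compound 2 to compound 3 (beyond the scatter). Because compound 2 only reached the limit (the limit of < 0.3 in this assay, at which 1 of the 2 values shown sits), the exact size of the return is uncertain. Compound 3 is therefore expected to give about 0.6 in this assay, between 0.4 and 0.8.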

Compound 3, hepatic extraction ratio: 0.6
Compound 3: middle estimate and measured number agree at the digits printed, and the stated range covers the measured number.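

In this assay, putting the 3-methoxyquinolin-4-yl group on a saturated chain carbon bound to an amine nitrogen in a ring gives a number at least 0.30 higher from compound 2 to compound 3 (beyond the scatter), so the low number of compound 2 does not carry over to every oxygen-bearing group at this place. The step on the other side is a number 0.10 lower from compound 1 to compound 3 (within the scatter), which means that this methoxy-bearing group and the group without oxygen in compound 1 cannot be told apart in this read-out. Compound 2 stands at a limit and not at an exact number, so the rise to compound 3 can be given only as a minimum: the limit of < 0.3 in this assay, at which 1 of the 3 values shown sits.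

The change to compound 3 swaps hydroxy for methoxy and also replaces a ring with one hetero atom by a ring of carbon only, and the compounds shown cannot separate these two changes. Also open, on these data alone, is how this assay would respond to a methoxy on the group of compound 2 with its two nitrogen-bearing rings kept, or to an amine or a fluorine on the carbon that carries the methoxy in compound 3.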